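A few compounds are considered here, and "the series" means these few. Any claim that something is new, unique, unknown or untested is made for them only; others in the source may bear on it.

Measured so far in an ADME assay on RAW264.7 cells (Mus musculus) for cytotoxicity, with a stated time of 24 h; a lower number here means a stronger inhibitor, a higher number a weaker inhibitor:
- compound 1 `COc1ccc(-c2cc(-c3ccc4c(c3)CCCC4)nc(NCc3ccccc3)c2C#N)cc1OC`: 4900 nM
- compound 2 `CCOC(=O)COc1nc(-c2ccc3c(c2)CCCC3)cc(-c2ccc(OC)c(OC)c2)c1C#N`: 26200 nM
- compound 3 `COc1ccc(-c2cc(-c3ccc4c(c3)CCCC4)nc(OCC(=O)NN)c2C#N)cc1OC`: 3100 nM

Compound 3 gives the lowest number of the three in this assay. Its nearest neighbour is compound 1, where a 1.6-fold lower number from compound 1 to compound 3 (0.20 log units; within the scatter), so the two are not separated; compound 2 stands clearly apart, since an 8.5-fold lower number from compound 2 to compound 3 (0.93 log units; beyond the scatter).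

Compound 4 `COc1ccc(-c2cc(-c3ccc4c(c3)CCCC4)nc(OCC(=O)NCc3ccccc3)c2C#N)cc1OC` differs from compound 3 by benzyl in place of amino on an amide-type nitrogen. Going by the values given here, no measured step changes the substituent on an amide-type nitrogen, so the nearest comparisons are indirect. The step from the ethoxy ester to the aminoamino group on the carbonyl carbon, an 8.5-fold lower number from compound 2 to compound 3 (0.93 log units; beyond the scatter), shows that this end of the side chain can move the number beyond the scatter. Compound 1 already carries a benzyl group, on the aromatic carbon, and a 1.6-fold lower number from compound 1 to compound 3 (0.20 log units; within the scatter) sits within the scatter, while a 5.3-fold higher number from compound 1 to compound 2 (0.73 log units; beyond the scatter) is modest. A benzyl on the amide-type nitrogen is therefore expected to give at most a modest shift, most likely towards a somewhat higher number, as a 1.6-fold higher number from compound 3 to compound 4 (0.21 log units; within the scatter). Compound 4 is thus estimated at 5000 nM in this assay, with a range from 1800 nM to 14000 nM.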

Compound 4, half-maximal inhibitory concentration: 8400 nM
For compound 4 the middle estimate is 1.7-fold (0.23 log units) below the measured one; the measured number falls inside the stated range.
By their numbers in this assay, from the lowest: compounds 3, 1 and 4 (each within the scatter of the next, the first and the last beyond it); then compound 2.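

In this assay, the substituent on the amide-type nitrogen proves able to move the number on its own: benzyl in place of amino gives a 2.7-fold higher number from compound 3 to compound 4 (0.43 log units; beyond the scatter), a modest step beyond the scatter. Benzylamino in place of ethoxy on the carbonyl carbon gives a 3.1-fold lower number from compound 2 to compound 4 (0.49 log units; beyond the scatter), so the ester remains clearly apart from both the aminoamino and the benzylamino side chains. The longer (benzylcarbamoyl)methoxy group in place of benzylamino on an aromatic carbon gives a 1.7-fold higher number from compound 1 to compound 4 (0.23 log units; within the scatter), which does not separate the two compounds.

No measurement shown here offers an explanation for these steps. Open, from the compounds shown here alone, is how a small methyl group on the amide-type nitrogen, or a carboxylic acid in place of the ester, would read in this assay.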